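The source may report more compounds than this note shows. Statements on the series, on what has been measured and on what is new or still open speak of the compounds shown alone.

Measured compounds in a functional assay on HCT-15 cells (Homo sapiens) for antiproliferative activity, read by sulforhodamine B assay, with a stated time of 48 h, tested at 50 uM; on this read-out lower numbers stand for less inhibition and higher numbers for more inhibition at the one concentration tested (going by the name of the read-out):
- compound 1 `CC1=CC[C@H](C(C)C)c2cc(C)c(OC(=O)c3ccc(C)cc3)cc21`: 78.9%
- compound 2 `CC1=CC[C@H](C(C)C)c2cc(C)c(OC(=O)Nc3ccccc3)cc21`: 92%
- compound 3 `COc1cccc(C(=O)Oc2cc3c(C)ccc(C(C)C)c3cc2C)c1`: 35.2%

Compound 1 stands second highest of the three numbers. Within the data shown here, its nearest neighbour is compound 2, reached by the one measured single-point step, a number 13.1 percentage points higher from compound 1 to compound 2 (beyond the scatter), which is beyond the scatter but modest. Among the measured compounds shown here, compound 3 differs from compound 1 in more than one place, so no single step is drawn; the two values show compound 3 far lower.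

Compound 4 `CC1=CC[C@H](C(C)C)c2cc(C)c(OC(=O)c3ccc(Cl)cc3)cc21` is the next member. Relative to compound 1 the change is chloro in place of methyl on an aromatic carbon. For the measured compounds named here, the one measured step concerns a different site, the group on the carbonyl carbon, so it bears only indirectly on this change; it shows that an exchange at the ester side can shift the read-out by a modest amount. A single exchange of one substituent for another of the same size on the aromatic ring gives no ground to expect more than a small step in this assay, in either direction, and most likely none beyond the scatter. Compound 4 is therefore expected near compound 1, with the step from compound 1 to compound 4 estimated as a number 0.9 percentage points lower from compound 1 to compound 4 (within the scatter). The estimate for compound 4 is 78%, expected to lie between 60% and 92%.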

Compound 4, a percentage reported as inhibition, at one concentration (the size of the read-out at that concentration, not a potency): 47.4%
Compound 4: middle estimate off by 30.6 percentage points, on the high side, outside the stated range (below it).
By their numbers in this assay, from the lowest: compound 3; then compound 4; then compound 1; then compound 2.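

In this assay, the aromatic carbon para to a large group proves to be a sensitive site: the exchange of 4-methylphenyl for 4-chlorophenyl gives a number 31.5 percentage points lower from compound 1 to compound 4 (beyond the scatter), so the read-out responds to this ring substituent as well as to the group on the carbonyl carbon. Replacing anilino on the carbonyl carbon with 4-chlorophenyl gives a number 44.6 percentage points lower from compound 2 to compound 4 (beyond the scatter), a large step that widens the spread among these single-place changes. No measurement shown accounts for the effect of the chloro group.

Open, going by these compounds, is whether the lower number follows from chloro entering or methyl leaving, which bromo, ethyl or an amine at the same carbon could help separate. Also open, on these data alone, is whether the same exchange on the anilino ring of compound 2 would give a similar step.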